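The compounds below may be only part of what the source reports. "The series", "measured", "known", "first", "only" and "open" are said of these compounds alone.

In a functional assay on KB cells (Homo sapiens) for antiproliferative activity, read by MTT assay, with a stated time of 48 h (on this read-out lower numbers stand for stronger inhibition and higher numbers for weaker inhibition), compound 1 `Cn1cc(C2=C(c3nn(CCCn4cncn4)c4ncccc34)C(=O)NC2=O)c2ccccc21` gives > 100000 nM, which is a limit of the assay. Compound 2 `Cn1cc(C2=C(c3nn(CCCn4cncn4)c4ncccc34)C(=O)N(c3ccccc3)C2=O)c2ccccc21` gives > 100000 nM, also only a limit, so any readable change from compound 2 can only point to stronger inhibition. Both results sit at the same limit: the limit of > 100000 nM in this assay, at which 2 of the 2 values shown sit. For the measured compounds named here, the one measured step, a step that the two limits leave unreadable from compound 1 to compound 2, has no readable size and lies elsewhere in the molecule, so it gives no guide here. Compound 3 `Cn1cc(C2=C(c3nn(CCCN4CCCCC4)c4ncccc34)C(=O)N(c3ccccc3)C2=O)c2ccccc21` carries a new group on the chain: piperidin-1-yl in place of 1H-1,2,4-triazol-1-yl on a saturated chain carbon, three bonds along the chain from an aromatic nitrogen. The expected change, loosely estimated, is an at least 3.3-fold lower number from compound 2 to compound 3 (0.52 log units; beyond the scatter). For compound 3 the estimated value is 30000 nM, with an expected range of 5000 nM to 100000 nM.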

Compound 3, half-maximal inhibitory concentration: 5600 nM
For compound 3 the middle estimate is 5.4-fold (0.73 log units) above the measured one, and the stated range covers the measured number.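

Exchanging 3-(1H-1,2,4-triazol-1-yl)propyl for 3-(piperidin-1-yl)propyl gives an at least 17-fold lower number from compound 2 to compound 3 (1.25 log units; beyond the scatter) in this assay, so a change at the end of this chain can move the read-out by a large amount. Compound 3 is the only compound shown that comes off the limit: the limit of > 100000 nM in this assay, at which 2 of the 3 values shown sit.

One swap cannot separate the aromatic triazole ring's loss from the change to a non-aromatic ring with a single nitrogen. Also open, from the compounds shown here alone, is how morpholin-4-yl, an open-chain amine such as dimethylamino, or a longer chain would read at this place.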